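Restoring the Amino Link: Expected Gain in Growth Inhibition

A few compounds are considered here, and "the series" means these few. Any claim that something is new, unique, unknown or untested is made for them only; others in the source may bear on it.

Within the data shown here, compound 2 `COc1cc(-c2nn(-c3cccc(NC(=O)c4ccc(Cl)c(C(F)(F)F)c4)c3)cc2-c2ccncc2)ccc1Cl` gives 13100 nM in a functional assay on HOP-62 cells (Homo sapiens) for inhibition, read by sulforhodamine B assay, with a stated time of 48 h (on this read-out lower numbers stand for stronger inhibition of growth and higher numbers for weaker inhibition of growth), the higher of the two numbers measured so far; compound 1 `COc1cc(-c2nn(-c3cccc(NC(=O)Nc4ccc(Cl)c(Cl)c4)c3)cc2-c2ccncc2)ccc1Cl` gives 1440 nM. Compound 3 `COc1cc(-c2nn(-c3cccc(NC(=O)Nc4ccc(Cl)c(C(F)(F)F)c4)c3)cc2-c2ccncc2)ccc1Cl` differs from compound 2 by (4-chloro-3-(trifluoromethyl)phenyl)amino in place of 4-chloro-3-(trifluoromethyl)phenyl on a carbonyl carbon. Among the measured compounds shown here, only one measured step bears on this change, and it runs in reverse: a 9.1-fold higher number from compound 1 to compound 2 (0.96 log units; beyond the scatter), where the amino link was removed together with a change of the aryl group. Putting the amino link back while keeping the aryl group is therefore expected to give compound 3 a lower number, a 7.3-fold lower number from compound 2 to compound 3 (0.86 log units; beyond the scatter). Compound 3 is estimated at 1800 nM, within a range from 600 nM to 5500 nM.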

Compound 3, concentration for 50% growth inhibition: 1310 nM
Compound 3: middle estimate off by 1.4-fold (0.14 log units), on the high side; low and high end bracket the measured number.
By their numbers in this assay, from the lowest: compounds 3 and 1 (each within the scatter of the next); then compound 2.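

With the aryl group held fixed, adding the amino link on the carbonyl carbon gives a 10-fold lower number from compound 2 to compound 3 (1.00 log units; beyond the scatter) in this assay and shows that this one change carries a large step without any change of aryl group. Trifluoromethyl in place of chloro on an aromatic carbon gives a 1.1-fold lower number from compound 1 to compound 3 (0.04 log units; within the scatter) and so does not separate the two compounds once the amino link is present. Still open, on these data alone, is whether a nitrile on that aromatic carbon, or a longer chain in place of the amino link, would keep growth inhibition at this level. No measurement shown says why the amino link matters.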